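The compounds below may be only part of what the source reports. "The series", "measured", "known", "first", "only" and "open" are said of these compounds alone.

In a functional assay on HepG2 cells (Homo sapiens) for cytotoxicity, read by sulforhodamine B assay, with a stated time of 48 h (a lower number here means a stronger inhibitor, a higher number a weaker inhibitor), compound 1 `COc1ccc(/C=C/C(=O)c2ccc(N)c(-c3ccc(F)cc3)c2)cc1` gives 3750 nM. Among the compounds with values here, compound 2 `O=C(/C=C/c1ccc(Br)cc1)c1cccc(-c2cccc(F)c2)c1` gives 9920 nM, the higher of the only two numbers available. That makes compound 2 the weaker inhibitor of the pair, by a gap beyond the usual scatter of repeated measurements.

Compound 3 `O=C(/C=C/c1cccc(Br)c1)c1cccc(-c2cccc(F)c2)c1` has the same atoms as compound 2, joined differently: 3-bromophenyl in place of 4-bromophenyl on a double-bonded chain carbon bound to a double-bonded chain carbon. Put simply, 3-bromophenyl stands in place of 4-bromophenyl on a double-bonded chain carbon bound to a double-bonded chain carbon.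

Within the data shown here, no measured pair shows a change of this kind, and the two measured compounds differ in more than one place. With no direct guide, the expectation in this assay is a step within the scatter, with neither direction favoured. The estimated change is small: a 1.1-fold lower number from compound 2 to compound 3 (0.04 log units; within the scatter). For compound 3 the expected value is 9000 nM, with an estimated range from 4500 nM to 18000 nM.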

Compound 3, half-maximal inhibitory concentration: 6980 nM
The estimate for compound 3 lay 1.3-fold (0.11 log units) above the measured number; measured number inside the range.
By their numbers in this assay, from the lowest: compounds 1, 3 and 2 (each within the scatter of the next, the first and the last beyond it).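

In this assay, putting 3-bromophenyl in place of 4-bromophenyl on a double-bonded chain carbon bound to a double-bonded chain carbon gives a 1.4-fold lower number from compound 2 to compound 3 (0.15 log units; within the scatter). Within the data shown here, this is the first direct reading at this position, since compound 1 and compound 2 differ in more than one place, and it shows that this exchange, which keeps the same atoms, does not separate the two compounds beyond the scatter. Nothing measured beyond these numbers bears on what lies behind this result.

On these data alone, whether a different group on this ring, such as a carboxylic acid or a dimethylamino group, would also stay within the scatter remains open. Also open, as far as these compounds go, is whether the same exchange would read alike on the core of compound 1, which carries other groups.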